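This account rests on a few compounds, and the source may have more. Where it says the series, first, only, none or still open, it means among the compounds named here.

Measured in a functional assay on HOP-62 cells (Homo sapiens) for inhibition, read by sulforhodamine B assay; on this read-out lower numbers stand for stronger inhibition of growth and higher numbers for weaker inhibition of growth:
- compound 1 `Fc1ccc(-c2ccc(-c3ccc(-c4nc5ccccc5[nH]4)cc3)cc2)cc1`: 39300 nM
- compound 2 `FC(F)(F)c1ccc(-c2ccc(-c3ccc(-c4nc5ccccc5[nH]4)cc3)cc2)cc1`: 100000 nM
- compound 3 `CN(C)c1ccc(-c2ccc(-c3ccc(-c4nc5ccccc5[nH]4)cc3)cc2)cc1`: 100000 nM

Compound 1 has the lowest number of the three. The measured steps are modest: a 2.5-fold higher number from compound 1 to compound 2 (0.41 log units; beyond the scatter) and a 2.5-fold higher number from compound 1 to compound 3 (0.41 log units; beyond the scatter). Between the other two there is none, no change at the digits printed from compound 2 to compound 3 (within the scatter).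

Compound 4 `Oc1cccc2[nH]c(-c3ccc(-c4ccc(-c5ccc(F)cc5)cc4)cc3)nc12` differs from compound 1 in one place, with hydroxy in place of hydrogen on an aromatic carbon of a six-membered aromatic ring of carbon only, part of a fused or bridged system of two rings: hydroxy in place of hydrogen on an aromatic carbon.

Within the data shown here, none of the measured steps adds hydroxy or touches that place, so they bear on this change only loosely. They give no direction and offer only a rough sense of size, as a modest step such as a 2.5-fold higher number from compound 1 to compound 2 (0.41 log units; beyond the scatter). A step of about that size is expected at most, with the direction left open and a slight lean towards a lower number. The estimated step is a 1.3-fold lower number from compound 1 to compound 4 (0.12 log units; within the scatter). For compound 4 the expected value is 30000 nM, within an estimated range of 10000 nM to 100000 nM.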

Compound 4, concentration for 50% growth inhibition: 8310 nM
Compound 4: middle estimate off by 3.6-fold (0.56 log units), on the high side; the whole stated range lies above it.
By their numbers in this assay, from the lowest: compound 4; then compound 1; then compounds 2 and 3 (each within the scatter of the next).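

In this assay, hydroxy in place of hydrogen on an aromatic carbon of the six-membered aromatic ring of carbon only, part of a fused or bridged system of two rings, gives a 4.7-fold lower number from compound 1 to compound 4 (0.67 log units; beyond the scatter) and so lies beyond the scatter. The earlier steps from compound 1 all changed the fluoro place and all raised the number, so this is the first change from compound 1 shown to lower it, and it does so at a different place. The data offer no measured evidence to explain this fall.

The compounds shown leave open whether methoxy or an amine on this same carbon would lower the number as hydroxy does. They also leave open whether hydroxy would have the same effect on the other carbons of this ring, or alongside trifluoromethyl or dimethylamino in place of fluoro.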